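The compounds below may be only part of what the source reports. "The series", "measured", "known", "first", "only" and "open" are said of these compounds alone.

Of the compounds shown here, two of a shared core have been measured in a functional assay on HEK293 cells for agonist activity at D(4) dopamine receptor (Homo sapiens), read by FLIPR; a higher number here means a larger maximal response, a lower number a smaller maximal response. Compound 1 `Cc1cccc(C(=O)NCN2CCC(c3cccc[n+]3[O-])CC2)c1` carries 3-methylphenyl on the carbonyl carbon, and in this assay compound 1 reaches 77%. Compound 2 `O=C(NCN1CCC(c2cccc[n+]2[O-])CC1)c1ccccn1` carries pyridin-2-yl in that position, and in this assay compound 2 reaches 40%. For the measured compounds named here, the single measured step between them is a number 37 percentage points lower from compound 1 to compound 2 (beyond the scatter). Compound 2 therefore stands lowest of the two measured numbers, and its nearest neighbour is compound 1.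

Compound 3 `Cc1ccc(C(=O)NCN2CCC(c3cccc[n+]3[O-])CC2)cc1C` differs from compound 2 in one place: 3,4-dimethylphenyl in place of pyridin-2-yl on a carbonyl carbon. Going by the values given here, the step that bears on this change is the one from compound 1 to compound 2, since it replaces an aromatic carbon ring bearing a methyl with pyridin-2-yl at the same carbonyl carbon and lowered the maximal response substantially. Compound 3 reverses that exchange, putting a methyl-bearing carbon ring back in place of pyridin-2-yl, so a rise of similar size in this assay is expected. For compound 3 the estimated maximal response is 75%, within 55% to 95%, which is expected to mean a step of a number 35 percentage points higher from compound 2 to compound 3 (beyond the scatter).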

Compound 3, largest response reached (reported as efficacy), in percent of the reference or control that the assay uses: 65%
Compound 3: middle estimate off by 10 percentage points, on the high side, within the range that was stated.
By their numbers in this assay, from the lowest: compound 2; then compound 3; then compound 1.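

In this assay, exchanging pyridin-2-yl for a carbon ring on the carbonyl carbon again gives a larger maximal response, with a number 25 percentage points higher from compound 2 to compound 3 (beyond the scatter), so the rise is not confined to the 3-methylphenyl group and also holds for 3,4-dimethylphenyl. For the compounds shown here, what the earlier compounds could not show is that the pattern of methyl groups on the carbon ring also matters at this position: methyl in place of hydrogen on an aromatic carbon gives a number 12 percentage points lower from compound 1 to compound 3 (beyond the scatter), so adding a methyl does not raise the response here. The position therefore responds both to the kind of ring and to what that carbon ring carries, and the extra methyl gives back part of what the carbon ring gains over pyridin-2-yl. No measurement at hand accounts for either step.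

The compounds shown leave open where an unsubstituted phenyl would stand, and so how much of the response depends on the ring itself and how much on its methyl groups. They also leave open whether a pyridin-2-yl carrying a methyl, or a phenyl carrying chlorine or a methoxy group, would follow the same pattern.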